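The source may report more compounds than this note shows. Statements on the series, on what has been measured and on what is new or still open speak of the compounds shown alone.

Working notes on the series.

Compound 1 `Cc1ccc(S(=O)(=O)N[C@@H](CC(=O)NC(C)(C)C)C(=O)NCCNC(=O)c2cc(C)ccc2F)cc1` and compound 2 `Cc1ccc(S(=O)(=O)N[C@@H](CC(=O)NC(C)(C)C)C(=O)NCCNC(=O)c2ccccc2F)cc1` share one core and differ in a single place, hydrogen in place of methyl on an aromatic carbon. In an ADME assay on Karpas-1106P cells (Homo sapiens) for cytotoxicity (a higher number here means that more compound is needed for the effect, a lower number that less compound is needed), compound 1 gives > 11100 nM, which is a limit of the assay and not a number. In this assay compound 2 likewise gives > 11100 nM, again a limit rather than a number. The step that the two limits leave unreadable from compound 1 to compound 2 therefore yields no size. All the evidence so far is the limit of > 11100 nM in this assay, at which 2 of the 2 values shown sit, so compound 2 stands at that limit, with no measured number and nothing in the series known to lie elsewhere.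

Compound 3 `Cc1ccc(S(=O)(=O)N[C@@H](CC(=O)NC(C)(C)C)C(=O)NCCNC(=O)c2cc(C)ccn2)cc1` is the next member, not yet measured in this assay. It differs from compound 2 in one place: 4-methylpyridin-2-yl in place of 2-fluorophenyl on a carbonyl carbon. Among the compounds with values here, no readable measured step bears on this exchange; the only step available, a step that the two limits leave unreadable from compound 1 to compound 2, sits between two limits, so no direction or size beyond the scatter is suggested. Compound 3 is expected to give about 15000 nM in this assay, within 5000 nM to 50000 nM, most likely again reported as a limit. The step that the limit leaves unreadable from compound 2 to compound 3 is accordingly expected to be negligible.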

Compound 3, half-maximal effective concentration: > 11100 nM
Compound 3 was reported as a limit; the forecaster's own chance of this, stated with the estimate: 75%; the middle value does not contradict the limit.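

Compound 3, like compound 1 and compound 2, is reported in this assay only as a limit and not as a number, so no new step can be read among the three: the limit of > 11100 nM in this assay, at which 3 of the 3 values shown sit.

The compounds shown leave open how far any of the three lies from that limit, and whether any exchange on this carbonyl carbon would give a readable number in this assay.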